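Removing a methoxy group from a triazole thioacetamide oxime

The compounds below may be only part of what the source reports. "The series", "measured", "known", "first", "only" and "open" are said of these compounds alone.

Two members of this series have been measured in a functional assay on the whole organism (strain albino) for inhibition, with Rattus norvegicus as the target, read by paw edema, with stated times of 30 min and 5 h, at a dose of 0.28 mmol/kg by the oral route; on this read-out lower numbers stand for less inhibition and higher numbers for more inhibition at the one dose given (going by the name of the read-out). Compound 1 `C=CCn1c(SCC(=O)Nc2ccc(/C(C)=N/O)cc2)nnc1-c1ccccc1` gives 71% in this assay. Compound 2 `CCn1c(SCC(=O)Nc2ccc(/C(C)=N/O)cc2)nnc1-c1ccc(OC)cc1` gives 65% in this assay, the lower of the two numbers, with compound 1 only slightly higher, a gap that lies within the scatter of repeated measurements. The two values therefore show no real difference between these compounds.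

Compound 3 `CCn1c(SCC(=O)Nc2ccc(/C(C)=N/O)cc2)nnc1-c1ccccc1` has not yet been measured in this assay. It differs from compound 2 by one change: hydrogen in place of methoxy on an aromatic carbon. Cut one bond further out, the change reads as 4-methoxyphenyl to phenyl.

Among the measured compounds shown here, no measured pair in this set isolates the same change, so the direction and size of its effect are unknown. The two measured compounds, which differ at this very position and elsewhere, give numbers within the scatter of each other. Compound 3 is therefore expected to stay close to compound 2, with a step of a number 3 percentage points higher from compound 2 to compound 3 (within the scatter) expected. The estimate for compound 3 in this assay is 68%, with a range from 55% to 80%.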

Compound 3, a percentage reported as inhibition, in the whole organism at one dose (the size of the read-out at that dose, not a potency): 66%
Compound 3: the middle estimate sits 2 percentage points above what was measured, within the range that was stated.
By their numbers in this assay, from the lowest: compounds 2, 3 and 1 (each within the scatter of the next).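

In this assay, replacing the methoxy group with hydrogen turns 4-methoxyphenyl into phenyl, and the step is a number 1 percentage points higher from compound 2 to compound 3 (within the scatter). Among the compounds shown here, this is the first comparison that isolates this position, and at the one dose given the read-out does not separate the two groups. Compound 3 also connects the two earlier compounds, which differed in more than one place: with methyl in place of vinyl on a saturated chain carbon bound to an aromatic nitrogen, the step is a number 5 percentage points lower from compound 1 to compound 3 (within the scatter), so neither single change moves the read-out beyond the scatter. No further data bear on these results or offer an account of them.

As far as these compounds go, it remains open whether an amine or a carboxylic acid in place of the methoxy group would leave the read-out just as unmoved, and whether a longer chain such as butyl on the aromatic nitrogen would do the same. From the compounds shown here alone, since the read-out gives the size of the inhibition at a single dose and not a potency, it is also open whether these compounds would separate at other doses.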